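The compounds below may be only part of what the source reports. "The series", "measured", "known", "first", "only" and "open" are said of these compounds alone.

Among the compounds with values here, in a functional assay on K562 cells (Homo sapiens) for cytotoxicity, read by trypan blue exclusion, with a stated time of 96 h (a higher number here means a weaker inhibitor, a lower number a stronger inhibitor), compound 3 `COC(=O)C(C)(C)Nc1cc(CS(=O)(=O)/C=C/c2c(OC)cc(OC)cc2OC)ccc1OC` gives 800 nM, the highest of the three numbers measured so far. Compound 1 `COc1cc(OC)c(/C=C/S(=O)(=O)Cc2ccc(OC)c(N)c2)c(OC)c1`, with a hydrogen on the nitrogen in question, gives 2.5 nM, and compound 2 `COC(=O)C(F)(F)Nc1cc(CS(=O)(=O)/C=C/c2c(OC)cc(OC)cc2OC)ccc1OC` gives 250 nM.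

Compound 4 `COC(=O)C(Nc1cc(CS(=O)(=O)/C=C/c2c(OC)cc(OC)cc2OC)ccc1OC)c1ccc(Cl)cc1` has not yet been measured. It carries (4-chlorophenyl)(methoxycarbonyl)methyl in place of 1-(methoxycarbonyl)-1-methylethyl on a nitrogen on an aromatic ring. All three measured steps concern this same nitrogen. Replacing the hydrogen gave large steps, a 100-fold higher number from compound 1 to compound 2 (2.00 log units; beyond the scatter) and a 320-fold higher number from compound 1 to compound 3 (2.51 log units; beyond the scatter). Exchanging one methoxycarbonyl-bearing group for another gave only a modest one, a 3.2-fold higher number from compound 2 to compound 3 (0.51 log units; beyond the scatter).

The change to compound 4 is an exchange of this second kind, but no measured group on that nitrogen contains a ring, so the estimate remains uncertain. In this assay, no step beyond the scatter is therefore expected. The expected change is a 1.6-fold lower number from compound 3 to compound 4 (0.20 log units; within the scatter). Compound 4 is estimated at 500 nM, with an expected range of 100 nM to 2000 nM.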

Compound 4, half-maximal inhibitory concentration: 200 nM
Compound 4: middle estimate off by 2.5-fold (0.40 log units), on the high side; low and high end bracket the measured number.
By their numbers in this assay, from the lowest: compound 1; then compounds 4 and 2 (each within the scatter of the next); then compound 3.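

With (4-chlorophenyl)(methoxycarbonyl)methyl, a group containing a ring is now seen on this nitrogen, and in this assay it gives a 4.0-fold lower number from compound 3 to compound 4 (0.60 log units; beyond the scatter) and so does not raise the number further than the ring-free 1-(methoxycarbonyl)-1-methylethyl group. Its exchange for difluoro(methoxycarbonyl)methyl gives a 1.3-fold lower number from compound 2 to compound 4 (0.10 log units; within the scatter) and places neither compound ahead of the other, so a six-membered aromatic ring on this carbon fits within the range already seen for the substituted compounds. Even so, the step from the free amine remains large, with an 80-fold higher number from compound 1 to compound 4 (1.90 log units; beyond the scatter) showing that this ring does not bring the number close to that of compound 1.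

The compounds shown leave open how a carboxylic acid in place of the methyl ester, or an unsubstituted phenyl ring in place of 4-chlorophenyl, would stand on this nitrogen. Nothing available accounts for the size of these steps.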